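This account rests on a few compounds, and the source may have more. Where it says the series, first, only, none or still open, it means among the compounds named here.

Compound 1 `Cn1c(=O)c(S(=O)(=O)c2ccc(F)cc2)cc2cnc(Nc3ccc4occc4c3)nc21`: 5000 nM
Compound 2 `Cn1c(=O)c(S(=O)(=O)Cc2ccc(F)cc2)cc2cnc(Nc3ccc4[nH]ccc4c3)nc21`: 30000 nM
Compound 3 `Cn1c(=O)c(S(=O)(=O)c2ccc(F)cc2F)cc2cnc(Nc3cnc4[nH]ccc4c3)nc21`: 750 nM

All three were tested in a functional assay on K562 cells (Homo sapiens) for inhibition, read by trypan blue exclusion, with a stated time of 72 h; a higher number here means a weaker inhibitor, a lower number a stronger inhibitor. Among these three, compound 2 stands at the highest number, making it the weakest inhibitor of the set; compound 1 sits nearest to it, compound 3 furthest away, and both gaps lie beyond the usual scatter.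

Compound 4 `Cn1c(=O)c(S(=O)(=O)Nc2ccc(F)cc2F)cc2cnc(Nc3ccc4[nH]ccc4c3)nc21` has not yet been measured. It differs from compound 2 in one place: (2,4-difluorophenyl)amino in place of 4-fluorobenzyl on a sulfonyl sulfur. The new group is the same ring, carrying the same two fluorines, as the one found on the sulfonyl sulfur of compound 3, although compound 3 also differs from compound 4 elsewhere, so the direction is only hinted at by the value of compound 3, 750 nM. On that basis a move toward a lower number is expected for compound 4, of moderate size, a 10-fold lower number from compound 2 to compound 4 (1.00 log units; beyond the scatter). In this assay compound 4 is therefore estimated at 3000 nM, with a plausible range from 800 nM to 12000 nM.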

Compound 4, half-maximal inhibitory concentration: 5000 nM
For compound 4 the middle estimate is 1.7-fold (0.22 log units) below the measured one; the measured number falls inside the stated range.
By their numbers in this assay, from the lowest: compound 3; then compounds 1 and 4 (each within the scatter of the next); then compound 2.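

Among these compounds, putting (2,4-difluorophenyl)amino in place of 4-fluorobenzyl on a sulfonyl sulfur gives a 6.0-fold lower number from compound 2 to compound 4 (0.78 log units; beyond the scatter) in this assay, the only comparison here between compounds that differ in one place. It shows that the group on this sulfur matters to the result: the size of the step lies beyond the scatter, and the entering group brings a ring attached through nitrogen and one hydrogen-bond donor. No measurement here bears on why the number moved.

This single step changes the attachment and the fluorine count together, and the compounds shown do not separate the two. Also open, going by these compounds, is how the number would respond to an unsubstituted phenylamino group, or to a simple chain such as methylamino, on the same sulfur.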